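This account rests on a few compounds, and the source may have more. Where it says the series, first, only, none or still open, it means among the compounds named here.

Measured in a functional assay on MCF7 cells (Homo sapiens) for antiproliferative activity, read by MTT assay, with a stated time of 48 h; a higher number here means a weaker inhibitor, a lower number a stronger inhibitor:
- compound 1 `COC(=O)/C(=C/c1ccccc1)CN1C(=O)[C@@H](OC)[C@H]1c1ccc(F)cc1`: 15600 nM
- compound 2 `COC(=O)/C(=C/c1ccccc1)CN1C(=O)[C@@H](OC)[C@H]1c1ccccc1`: 12900 nM

Compound 1 stands level with compound 2, as a 1.2-fold lower number from compound 1 to compound 2 (0.08 log units; within the scatter) shows. Compound 3 `CCOC(=O)/C(=C/c1ccccc1)CN1C(=O)[C@@H](OC)[C@H]1c1ccc(F)cc1` differs from compound 1 by methyl in place of hydrogen on a saturated chain carbon bound to an oxygen next to a carbonyl group, which turns methoxycarbonyl to ethoxycarbonyl. Going by the values given here, no measured step covers this place. The only one available, a 1.2-fold lower number from compound 1 to compound 2 (0.08 log units; within the scatter), is a change of hydrogen in place of fluoro on an aromatic carbon and bears on it only loosely. No step beyond the scatter is therefore expected in this assay, in either direction. Compound 3 is estimated at 14000 nM, with an expected range of 6000 nM to 32000 nM. This estimate means an expected 1.1-fold lower number from compound 1 to compound 3 (0.05 log units; within the scatter).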

Compound 3, half-maximal inhibitory concentration: 18800 nM
Beside the measured number, compound 3's estimate is 1.3-fold (0.13 log units) below it; the measured number falls inside the stated range.
By their numbers in this assay, from the lowest: compounds 2, 1 and 3 (each within the scatter of the next).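

At the ester, the only step shown at this place, methoxycarbonyl to ethoxycarbonyl in this assay gives a 1.2-fold higher number from compound 1 to compound 3 (0.08 log units; within the scatter), so adding this one methyl leaves the number within the scatter. Like the fluoro to hydrogen step on the aromatic carbon, this change does not separate the compounds. No supporting data bear on this result.

On these data alone, whether a longer chain such as butoxycarbonyl would hold the number stays open. So does the outcome of replacing the ester with a carboxylic acid or an amide.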